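This account rests on a few compounds, and the source may have more. Where it says the series, first, only, none or still open, it means among the compounds named here.

In a functional assay on MCF7 cells (Homo sapiens) for cytotoxicity, read by neutral red uptake, with a stated time of 3 days (a higher number here means a weaker inhibitor, a lower number a stronger inhibitor), three compounds built on one shared core have been measured. Compound 1 `CCc1c(F)c(N)c2c(=O)cc(-c3ccc(N)c(F)c3)oc2c1F` gives 130 nM. Compound 2 `COc1c(F)c(N)c2c(=O)cc(-c3ccc(N)c(F)c3)oc2c1F` gives 100 nM, and compound 3 `CN(C)CCC(=O)OCc1c(F)c(N)c2c(=O)cc(-c3ccc(N)c(F)c3)oc2c1F` gives 19 nM. Among these three numbers compound 2 stands second highest: the change a 1.3-fold lower number from compound 1 to compound 2 (0.11 log units; within the scatter) lies within the scatter, while a 5.3-fold lower number from compound 2 to compound 3 (0.72 log units; beyond the scatter) goes beyond it, as does a 6.8-fold lower number from compound 1 to compound 3 (0.84 log units; beyond the scatter).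

Compound 4 `CN(C)Cc1c(F)c(N)c2c(=O)cc(-c3ccc(N)c(F)c3)oc2c1F` has not yet been measured. It differs from compound 2 in one place: (dimethylamino)methyl in place of methoxy on an aromatic carbon. The measured step that bears most on this change is a 5.3-fold lower number from compound 2 to compound 3 (0.72 log units; beyond the scatter), where the methoxy was likewise replaced by a group carrying a dimethylamino nitrogen, although that group is longer and contains a carbonyl. The step from compound 1 to compound 2 shows that exchanging one small group for another on the same aromatic carbon changed little. Because a 5.3-fold lower number from compound 2 to compound 3 (0.72 log units; beyond the scatter) was modest, a modest step in the same direction is expected here, tempered by the entering group being shorter and lacking the carbonyl. Compound 4 is therefore estimated at 40 nM, with a range from 15 nM to 130 nM. The expected step is a 2.5-fold lower number from compound 2 to compound 4 (0.40 log units; beyond the scatter).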

Compound 4, half-maximal inhibitory concentration: 72 nM
Beside the measured number, compound 4's estimate is 1.8-fold (0.26 log units) below it; the measured number falls inside the stated range.
By their numbers in this assay, from the lowest: compound 3; then compounds 4, 2 and 1 (each within the scatter of the next).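

In this assay, (dimethylamino)methyl on this aromatic carbon, ortho to two fluoro groups, gives a 1.4-fold lower number from compound 2 to compound 4 (0.14 log units; within the scatter) and also a 1.8-fold lower number from compound 1 to compound 4 (0.26 log units; within the scatter) in place of the smaller methoxy and ethyl-bearing forms, so a dimethylamino nitrogen held on a short chain here does not set compound 4 apart from compound 1 or compound 2. The step of a 3.8-fold higher number from compound 3 to compound 4 (0.58 log units; beyond the scatter) shows that compound 3 does stand apart from compound 4, even though both carry the dimethylamino nitrogen, so the nitrogen alone does not account for the lower number of compound 3, which goes with the whole ((2-(dimethylamino)ethyl)carbonyl)oxy group. No measurement is available that would explain this difference.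

The compounds shown leave open whether the lower number of compound 3 goes with the carbonyl and its oxygen or with the greater length of the chain. A longer carbon chain ending in dimethylamino with no carbonyl, or an acetoxymethyl group with no amine, would separate those two features at this same carbon.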